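Cyclohexylmethyl replaces 3-chlorobenzyl on the shared core

The source may report more compounds than this note shows. Statements on the series, on what has been measured and on what is new or still open speak of the compounds shown alone.

Working notes on the series. Going by the values given here, in an assay on isolated protein for inhibition of protein deacetylase HDAC6 (Homo sapiens), with a stated time of 60 min (a higher number here means a weaker inhibitor, a lower number a stronger inhibitor), compound 1 `O=C(CCCCCCn1cc(Nc2ncc3ccn(Cc4cccc(F)c4)c3n2)cn1)NO` gives 14.7 nM and compound 2 `O=C(CCCCCCn1cc(Nc2ncc3ccn(Cc4cccc(Cl)c4)c3n2)cn1)NO` gives 36.8 nM; compound 2 stands highest of the two numbers, its only neighbour being compound 1. Among the compounds with values here, the single measured step, a 2.5-fold higher number from compound 1 to compound 2 (0.40 log units; beyond the scatter), swaps one halogen for another on the same aromatic ring and bears only loosely on the change now followed, (cyclohexyl in place of 3-chlorophenyl on a saturated chain carbon bound to an aromatic nitrogen), which yields compound 3 `O=C(CCCCCCn1cc(Nc2ncc3ccn(CC4CCCCC4)c3n2)cn1)NO`. Within the data shown here, no measured step exchanges an aromatic ring for a saturated one. A modest step of uncertain direction is therefore expected, a 1.2-fold lower number from compound 2 to compound 3 (0.09 log units; within the scatter), and the estimate for compound 3 is 30 nM, from 10 nM to 100 nM.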

Compound 3, half-maximal inhibitory concentration: 88 nM
The estimate for compound 3 lay 2.9-fold (0.47 log units) below the measured number, within the range that was stated.
By their numbers in this assay, from the lowest: compound 1; then compound 2; then compound 3.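

In this assay, going by these compounds alone, cyclohexyl on a saturated chain carbon bound to an aromatic nitrogen gives the first comparison of a saturated ring with an aromatic one at this position, with a 2.4-fold higher number from compound 2 to compound 3 (0.38 log units; beyond the scatter) and a 6.0-fold higher number from compound 1 to compound 3 (0.78 log units; beyond the scatter). Both halogen-bearing aromatic rings therefore give lower numbers than cyclohexyl, and compound 3 stands highest of the three. No available evidence bears on the reason for this difference.

As far as these compounds go, whether unsubstituted phenyl would match the halogenated rings remains open. So does the effect of an amine or a carboxylic acid on the cyclohexyl ring.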